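Aminopyridyl to dimethylaminopyridyl exchange: expected efficacy of compound 4

The source may hold more compounds than are shown below. What is called first, only, known or untested is meant among the compounds shown, and "the series" means these compounds.

Three compounds of the series have been run in an in vitro functional assay on HEK285-7 cells for antagonist activity at prostaglandin D2 receptor 2 (Homo sapiens), read by BRET and beta-arrestin recruitment; a lower number here means a smaller maximal response, a higher number a larger maximal response. Compound 1 `O=C(O)Cc1sc(C(c2ccccc2)c2ccccc2)nc1-c1ccc(F)cc1` gives 80% in this assay, compound 2 `O=C(O)Cc1sc(COc2ccc(Cl)cc2)nc1-c1ccc(Cl)cc1` gives 50%, and compound 3 `Nc1cc(-c2nc(C(c3ccc(F)cc3)c3ccc(F)cc3)sc2CC(=O)O)cc(F)n1` gives 30%. Compound 3 thus stands lowest of the three numbers: its nearest neighbour is compound 2, whose value is higher by a margin beyond the scatter, and the furthest is compound 1, higher still and again beyond the scatter. No two of the measured compounds differ in only one place, so none of these gaps can be tied to a single structural change.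

Compound 4 `CN(C)c1cc(-c2nc(C(c3ccc(F)cc3)c3ccc(F)cc3)sc2CC(=O)O)ccn1` is the next member awaiting measurement in this assay. It differs from compound 3 in one place: 2-(dimethylamino)pyridin-4-yl in place of 2-amino-6-fluoropyridin-4-yl on an aromatic carbon. A hydrogen-bond donor is lost and a fluorine leaves with it, while the heavy-atom count rises by one. Among the measured compounds shown here, nothing among the measured pairs isolates this kind of change, so the direction is open. A step of moderate size upward, towards the mid-range occupied by compound 2, is expected, a number 10 percentage points higher from compound 3 to compound 4 (within the scatter), but a result within the scatter of compound 3 cannot be excluded. Compound 4 is therefore estimated at 40%, with a range from 15% to 70%.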

Compound 4, largest response reached (reported as efficacy), in percent of the reference or control that the assay uses: 80%
Compound 4: the middle estimate sits 40 percentage points below what was measured; measured number above the stated range.
By their numbers in this assay, from the lowest: compound 3; then compound 2; then compounds 1 and 4 (each within the scatter of the next).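

Among the compounds shown here, this position is not silent: with the rest of compound 3 unchanged, exchanging 2-amino-6-fluoropyridin-4-yl for 2-(dimethylamino)pyridin-4-yl on the aromatic carbon next to the ring nitrogen gives, in this assay, a number 50 percentage points higher from compound 3 to compound 4 (beyond the scatter), the first change that can be tied to a single place. The step comes with a shift from 1 hydrogen-bond donor to 0, the departure of the fluorine and a rise from 8 to 9 heavy atoms, while the hydrogen-bond acceptor count of 2 and the six-membered aromatic ring stay the same, so a shared ring and acceptor count do not by themselves fix the maximal response. Nothing at hand indicates why the response moves with this exchange.

The compounds shown leave open which part of the exchange carries the step, since the amino hydrogens, the fluorine and the two methyl groups all change together. A 2-aminopyridin-4-yl or a 2-(methylamino)pyridin-4-yl group would separate these parts, and a 2-(dimethylamino)-6-fluoropyridin-4-yl group would show whether the fluorine matters once the dimethylamino group is in place.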